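Swapping one aromatic group on compound 3

The source may hold more compounds than are shown below. What is called first, only, known or untested is meant among the compounds shown, and "the series" means these compounds.

Three compounds have numbers in a functional assay on HL-60 cells (Homo sapiens) for cytotoxicity, read by WST assay, with a stated time of 48 h; a higher number here means that more compound is needed for the effect, a lower number that less compound is needed. Compound 1 `O=C1OC[C@H](Cc2ccccc2)[C@H]1Cc1cc(Cl)cc(Cl)c1` gives 23000 nM, compound 2 `C[C@H](Cc1ccccc1)[C@H](C)Cc1ccc(Cl)c(Cl)c1` gives 19000 nM, and compound 3 `Cc1cccc(C[C@H]2COC[C@@H]2Cc2ccc(Cl)c(Cl)c2)c1` gives 28000 nM. Compound 3 therefore stands level with the other two, since its gaps to both lie within the usual scatter of repeated measurements and its number cannot be ranked against theirs.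

The next molecule is compound 4 `Fc1ccc(C[C@H]2COC[C@@H]2Cc2ccc(Cl)c(Cl)c2)cc1`. It has 4-fluorophenyl in place of 3-methylphenyl on a saturated chain carbon bound to a saturated ring carbon. Among the measured compounds shown here, no measured pair differs in just one place, so the data give no direct guide to this change. Even so, compound 2 at 19000 nM and compound 3 at 28000 nM stay within the scatter of each other despite their different structures. No step beyond the scatter, in either direction, is therefore expected in this assay. The estimate amounts to an expected 1.1-fold lower number from compound 3 to compound 4 (0.05 log units; within the scatter). Compound 4 is expected at 25000 nM, within an estimated range of 12000 nM to 50000 nM.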

Compound 4, half-maximal effective concentration: 43000 nM
The estimate for compound 4 lay 1.7-fold (0.24 log units) below the measured number, within the range that was stated.
By their numbers in this assay, from the lowest: compounds 2, 1, 3 and 4 (each within the scatter of the next, the first and the last beyond it).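

Among the compounds shown here, this is the first pair of compounds that differ in one place only, so it gives the first direct reading of a change on a saturated chain carbon bound to a saturated ring carbon: in this assay, 4-fluorophenyl in place of 3-methylphenyl gives a 1.5-fold higher number from compound 3 to compound 4 (0.19 log units; within the scatter). Within the scatter, this swap between two aromatic groups with the same count of heavy atoms cannot be told apart from the spread of repeated measurements. No measured information on the two groups bears on this result.

As far as these compounds go, whether an amine, a carboxylic acid or a longer chain at this place would give a step beyond the scatter remains open. From the compounds shown here alone, it is also open whether the same swap would stay within the scatter on the core of compound 1.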